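The source may hold more compounds than are shown below. What is called first, only, known or untested is meant among the compounds shown, and "the series" means these compounds.

Measured compounds:
compound 1 `CS(=O)(=O)CCCn1c(Cn2c(=O)n(C3CC3)c3ccncc32)cc2cc(Cl)ccc21` — in an ADME assay on HeLa cells (Homo sapiens) for cytotoxicity, read by ATP content, with a stated time of 3 days (on this read-out lower numbers stand for higher toxicity in this test and higher numbers for lower toxicity in this test), compound 1 gives > 50000 nM, a limit of the assay.
compound 2 `O=c1n(Cc2cc3cc(Cl)ccc3n2CCCCF)c2cnccc2n1C1CC1` — in this assay compound 2 gives > 50000 nM, also a limit.

Compound 2 thus stands only at the assay limit, where both values shown sit (the limit of > 50000 nM in this assay, at which 2 of the 2 values shown sit). Compound 3 `O=c1n(Cc2cc3cc(Cl)ccc3n2CCCC(F)(F)F)c2cnccc2n1C1CC1` differs from compound 2 by trifluoromethyl in place of fluoromethyl on a saturated chain carbon, three bonds along the chain from an aromatic nitrogen. Going by the values given here, the one step on record, a step that the two limits leave unreadable from compound 1 to compound 2, is unreadable between two limits, so no size can be taken from it. The expectation for compound 3 is a step that the limit leaves unreadable from compound 2 to compound 3, that is, none beyond the scatter. Compound 3 is estimated at 60000 nM, within 30000 nM to 150000 nM, most likely reported again only as a limit.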

Compound 3, half-maximal cytotoxic concentration: > 50000 nM
Compound 3 ended at the assay's limit; the forecaster's own chance of this, stated with the estimate: 85%; the middle value does not contradict the limit.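

No step can be read between compound 1, compound 2 and compound 3, as each gives only a limit: the limit of > 50000 nM in this assay, at which 3 of the 3 values shown sit.

On these data alone, whether methylsulfonyl, fluoromethyl and trifluoromethyl on this chain differ at all in this assay stays open.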